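This account rests on a few compounds, and the source may have more. Where it says the series, first, only, none or still open, it means among the compounds named here.

Measured compounds:
- Compound 2 `Cc1nn(-c2ncnc3nc[nH]c23)c2c1C(OC1CCCC1)CC(=O)N2`: 62 nM
- Compound 3 `Cc1nn(-c2ncnc3nc[nH]c23)c2c1C(OCc1ccccc1F)CC(=O)N2`: 78 nM
- Compound 1 `Cc1nn(-c2ncnc3nc[nH]c23)c2c1C(OCC(=O)c1ccc(F)cc1)CC(=O)N2`: 973 nM

In a functional assay on HEK293 cells for agonist activity at G-protein coupled receptor 39 (Homo sapiens), read by scintillation proximity assay and inositol phosphate accumulation, with a stated time of 75 min (on this read-out higher numbers stand for an effect only at larger amounts of compound and lower numbers for an effect already at smaller amounts), compound 2 gives 62 nM, the lowest of the three numbers. Compound 3 sits close by, within the usual scatter, and compound 1 is far off, with a 16-fold lower number from compound 1 to compound 2 (1.20 log units; beyond the scatter) and a 12-fold lower number from compound 1 to compound 3 (1.10 log units; beyond the scatter) marking the two large steps in the set. Among the measured compounds shown here, the only step that stays within the scatter is a 1.3-fold higher number from compound 2 to compound 3 (0.10 log units; within the scatter).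

Compound 4 `Cc1nn(-c2ncnc3nc[nH]c23)c2c1C(OCc1ccccc1C#N)CC(=O)N2` has not yet been measured. It differs from compound 2 by 2-cyanobenzyl in place of cyclopentyl on an oxygen on a saturated carbon. The step that bears most on this change is a 1.3-fold higher number from compound 2 to compound 3 (0.10 log units; within the scatter), where another benzyl group on the same oxygen took the place of cyclopentyl and the number barely moved. Compound 1 shows that a carbonyl-bearing chain on that oxygen costs much more, but compound 4 carries no such chain, so that step is only a distant reference.

From this the step expected for compound 4 in this assay is small, a 1.5-fold higher number from compound 2 to compound 4 (0.16 log units; within the scatter), likely within the scatter, perhaps edging upward. Compound 4 is therefore estimated at 90 nM, with a range from 35 nM to 250 nM.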

Compound 4, half-maximal effective concentration: 127 nM
The estimate for compound 4 lay 1.4-fold (0.15 log units) below the measured number; low and high end bracket the measured number.
By their numbers in this assay, from the lowest: compounds 2, 3 and 4 (each within the scatter of the next, the first and the last beyond it); then compound 1.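

With a nitrile on the benzyl group, the oxygen on the saturated carbon gives the first step away from cyclopentyl that goes beyond the scatter, although it is only modest: a 2.0-fold higher number from compound 2 to compound 4 (0.31 log units; beyond the scatter). Cyano in place of fluoro on an aromatic carbon, a change not seen among the earlier compounds, does not separate the two benzyl groups in this assay, with a 1.6-fold higher number from compound 3 to compound 4 (0.21 log units; within the scatter). The 2-cyanobenzyl group also stays clearly apart from the ((4-fluorophenyl)carbonyl)methyl group, with a 7.7-fold lower number from compound 1 to compound 4 (0.88 log units; beyond the scatter), so the large cost seen with that chain does not return with the nitrile.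

Nothing among the data shown accounts for any of these steps. The compounds shown leave open whether an amine or a carboxylic acid on the aromatic ring, or a longer chain joining that ring to the oxygen, would keep the number within the scatter of compound 2 or move it as far as the carbonyl-bearing chain of compound 1 does.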